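A few compounds are considered here, and "the series" means these few. Any claim that something is new, unique, unknown or untested is made for them only; others in the source may bear on it.

Compound 1 `COc1cc(Cl)cc(-c2nn(-c3cccc(NC(=O)Nc4cccc(C(F)(F)F)c4)c3)cc2-c2ccncc2)c1`: -3%
Compound 2 `COc1cc(Cl)cc(-c2nn(-c3cccc(NC(=O)Nc4ccc(Cl)c(C(F)(F)F)c4)c3)cc2-c2ccncc2)c1`: -39%
Compound 3 `O=C(Nc1cccc(-n2cc(-c3ccncc3)c(-c3cc(O)cc(Cl)c3)n2)c1)c1cc(C(F)(F)F)cc(C(F)(F)F)c1`: 30%

In a functional assay on SK-OV-3 cells (Homo sapiens) for inhibition, read by sulforhodamine B assay, with a stated time of 48 h, tested at 100 uM (a lower number here means a stronger effect, a higher number a weaker effect of the compound at the concentration tested), compound 2 gives the lowest of the three numbers, so its effect at the tested concentration is the strongest seen here; its gaps to compound 1 and to compound 3 both lie beyond the scatter. Compound 4 `O=C(Nc1cccc(-n2cc(-c3ccncc3)c(-c3cc(O)cc(Cl)c3)n2)c1)Nc1ccc(Cl)c(C(F)(F)F)c1` differs from compound 2 by hydrogen in place of methyl on an oxygen on an aromatic ring. Within the data shown here, the only single-change step measured, a number 36 percentage points lower from compound 1 to compound 2 (beyond the scatter), concerns chloro entering elsewhere in the molecule and says nothing about the oxygen. Compound 3 carries hydroxy but also differs from compound 2 in a second place; in this assay compound 3 gives 30%, so no clean comparison exists. The number for compound 4 is therefore expected close to compound 2, with a step of a number 14 percentage points higher from compound 2 to compound 4 (beyond the scatter) inside the scatter. The estimate for compound 4 is -25%, from -65% to 20%.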

Compound 4, a percentage reported as activity, at one concentration (the size of the read-out at that concentration, not a potency): -15%
For compound 4 the middle estimate is 10 percentage points below the measured one; low and high end bracket the measured number.
By their numbers in this assay, from the lowest: compound 2; then compound 4; then compound 1; then compound 3.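

In this assay, going from 3-chloro-5-methoxyphenyl to 3-chloro-5-hydroxyphenyl gives a number 24 percentage points higher from compound 2 to compound 4 (beyond the scatter), so removing this methyl weakens the effect at the tested concentration. Among these compounds, this is the first clean reading at this oxygen, since the earlier single-change step concerned chloro entering elsewhere in the molecule. Nothing available gives a reason for this step.

Still open, from the compounds shown here alone, is how an ethoxy group, a longer chain on the oxygen, or an amine in place of the oxygen would compare with compound 2 and compound 4.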